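This account rests on a few compounds, and the source may have more. Where it says the series, first, only, none or still open, it means among the compounds named here.

Compound 1 `Cc1cccc(Cn2c(CN3CCN(C(=O)C4CCCC4)CC3)nc3ccccc32)c1` has the highest number of the three compounds that have been measured in an assay on isolated protein for inhibition of aldehyde dehydrogenase 1A1 (Homo sapiens), read by spectrophotometry, tested at 10 uM; a lower number here means less inhibition, a higher number more inhibition at the concentration tested (going by the name of the read-out): compound 1 gives 67.5%. Compound 2 `O=C(C1CC1)N1CCN(Cc2nc3ccccc3n2Cc2ccc(C(F)(F)F)cc2)CC1` gives 37% in this assay, and compound 3 `CCCCn1c(CN2CCN(C(=O)C3CC3)CC2)nc2ccccc21` gives 18.2%, both beyond the scatter from compound 1. Among the compounds with values here, compound 1 and compound 2 differ in two places at once, so their values show only that compound 1 sits higher. Within the data shown here, the one single-point step available, a number 18.8 percentage points lower from compound 2 to compound 3 (beyond the scatter), concerns the group on the saturated chain carbon bound to the aromatic nitrogen, not the amide end.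

Compound 4 `Cc1cccc(Cn2c(CN3CCN(C(=O)c4ccco4)CC3)nc3ccccc32)c1` has not yet been measured. It differs from compound 1 at the carbonyl carbon whose other neighbour is the amide-type nitrogen in a ring: furan-2-yl in place of cyclopentyl on a carbonyl carbon. Among the measured compounds shown here, no measured step touches this carbonyl position, so the measured step from compound 2 to compound 3 does not bear on it, and nothing in the measured compounds says how a five-membered aromatic ring with one hetero atom compares with a five-membered non-aromatic ring of carbon only at this place. Compound 4 is therefore expected to remain in the region of compound 1, with a modest downward step, a number 12.5 percentage points lower from compound 1 to compound 4 (beyond the scatter), allowed for the uncertainty. The estimate for compound 4 in this assay is 55%, within a range from 30% to 78%.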

Compound 4, a percentage reported as inhibition, at one concentration (the size of the read-out at that concentration, not a potency): 73.2%
Compound 4: middle estimate off by 18.2 percentage points, on the low side, and the stated range covers the measured number.
By their numbers in this assay, from the lowest: compound 3; then compound 2; then compounds 1 and 4 (each within the scatter of the next).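

Within the data shown here, the first measured change at the carbonyl carbon whose other neighbour is the amide-type nitrogen in a ring, furan-2-yl in place of cyclopentyl, reads in this assay as a number 5.7 percentage points higher from compound 1 to compound 4 (within the scatter). With the rest of compound 1 held fixed, this read-out therefore does not separate a five-membered non-aromatic ring of carbon only from a five-membered aromatic ring with 1 hetero atom and 1 hydrogen-bond acceptor, so this position accepts that exchange without a change beyond the scatter at the one concentration tested. Nothing measured on these compounds accounts for this match between the two groups.

From the compounds shown here alone, it remains open whether the position would accept groups of another kind, such as a phenyl ring, a longer chain, an amine or a carboxylic acid, and whether furan-2-yl would give a similar result in place of the amide end of compound 2 or compound 3. Because each number comes from a single concentration, the compounds shown also leave open whether compound 1 and compound 4 would still match in potency.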